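The source may report more compounds than this note shows. Statements on the series, on what has been measured and on what is new or still open speak of the compounds shown alone.

Working notes on the series.

Three compounds share a core and have been run in a functional assay on RXF 393 cells (Homo sapiens) for cytotoxicity, read by sulforhodamine B assay, with a stated time of 48 h, tested at 0.01 uM; on this read-out higher numbers stand for a weaker effect at the one concentration tested and lower numbers for a stronger effect. Compound 1 `COc1cc(-c2cc(/C=C/C(=O)c3ccc(N)cc3)[nH]n2)cc(OC)c1OC` gives 91% in this assay. Compound 2 `COc1ccc(C(=O)/C=C/c2cc(-c3cc(OC)c(OC)c(OC)c3)n[nH]2)cc1OC` gives 100%, and compound 3 `COc1ccc(C(=O)/C=C/c2cc(-c3cc(OC)c(OC)c(OC)c3)n[nH]2)cc1` gives 93%. All three numbers sit close together; a number 9 percentage points higher from compound 1 to compound 2 (within the scatter), a number 2 percentage points higher from compound 1 to compound 3 (within the scatter) and a number 7 percentage points lower from compound 2 to compound 3 (within the scatter) are each within the scatter, so nothing separates them.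

The change from compound 2 to compound 3 is hydrogen in place of methoxy on an aromatic carbon. The same kind of change is now made from compound 1 to compound 4 `COc1ccc(-c2cc(/C=C/C(=O)c3ccc(N)cc3)[nH]n2)cc1OC`, namely (hydrogen in place of methoxy on an aromatic carbon). The surroundings differ: in compound 1 the position is also meta to a methoxy group, which the position in compound 2 is not. The cores of compound 1 and compound 2 differ by 4-aminophenyl in place of 3,4-dimethoxyphenyl on a carbonyl carbon.

For compound 4 in this assay a step of about a number 1 percentage points lower from compound 1 to compound 4 (within the scatter) is expected, resting on compound 2 and compound 3, where a number 7 percentage points lower from compound 2 to compound 3 (within the scatter) stayed within the scatter. The estimate for compound 4 is 90%, with a range from 76% to 100%.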

Compound 4, a percentage reported as activity, at one concentration (the size of the read-out at that concentration, not a potency): 99%
The estimate for compound 4 lay 9 percentage points below the measured number; low and high end bracket the measured number.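

In this assay the new step, a number 8 percentage points higher from compound 1 to compound 4 (within the scatter), is small taken alone, but it does not match the earlier step on the other core: the same change on two cores in this assay, a number 7 percentage points lower (within the scatter) from compound 2 to compound 3 and a number 8 percentage points higher (within the scatter) from compound 1 to compound 4, 15 percentage points apart, beyond the scatter of two such steps

Hydrogen in place of methoxy on an aromatic carbon therefore does not carry from the core of compound 2 to the core of compound 1 as a fixed step. This does not show the source of the mismatch: the cores differ on the carbonyl carbon and the position in compound 1 is also meta to a methoxy group, with one pair per core to separate the two, and neither step alone lies beyond the scatter.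

Open, on these data alone, is how this position behaves with groups other than methoxy and hydrogen, such as hydroxy, ethoxy or chlorine, on either core. Also open, as far as these compounds go, is whether a further core, for example one with a carboxylic acid in place of the amino group, would follow compound 1 or compound 2.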